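Fluoro Swaps Measured, Now a Change at the Carbonyl

The source may hold more compounds than are shown below. What is called first, only, known or untested is meant among the compounds shown, and "the series" means these compounds.

In a functional assay on HL-60 cells (Homo sapiens) for antiproliferative activity (on this read-out lower numbers stand for stronger inhibition and higher numbers for weaker inhibition), compound 1 `CCOC(=O)c1ccc(Oc2ccc(OC)cc2)cc1` gives only a limit, > 20000 nM. Compound 3 `CCOC(=O)c1ccc(Oc2ccc(F)c(F)c2)cc1` also gives only a limit, > 30000 nM. Compound 2 `CCOC(=O)c1ccc(Oc2ccc(OC)c(F)c2)cc1` is the only one of the three with an actual number, 3500 nM. Fluoro in place of hydrogen on an aromatic carbon gave an at least 5.7-fold lower number from compound 1 to compound 2 (0.75 log units; beyond the scatter), and fluoro in place of methoxy on an aromatic carbon gave an at least 8.5-fold higher number from compound 2 to compound 3 (0.93 log units; beyond the scatter). Compound 4 `COc1ccc(Oc2ccc(C(=O)NC3CC3)cc2)cc1F` instead has cyclopropylamino in place of ethoxy on a carbonyl carbon. Neither measured step changed that carbonyl carbon, so they suggest no size or direction, and no shift beyond the scatter is expected. The expected step is a 1.2-fold lower number from compound 2 to compound 4 (0.07 log units; within the scatter). In this assay, the estimated value for compound 4 is 3000 nM, with an expected range of 300 nM to 25000 nM.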

Compound 4, half-maximal inhibitory concentration: 14100 nM
Estimate against measurement, compound 4: 4.7-fold (0.67 log units) below, within the range that was stated.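

Among the compounds shown here, this is the first look at the carbonyl carbon: cyclopropylamino in place of ethoxy gave a 4.0-fold higher number from compound 2 to compound 4 (0.61 log units; beyond the scatter) in this assay, so what sits at this position does matter. The swap brings in a hydrogen-bond donor and a ring, and inhibition weakens, yet compound 4 still gives an actual number rather than a limit. Nothing shown here explains the weaker inhibition. On these data alone, whether methylamino or a free carboxylic acid at this carbonyl would keep the activity of compound 2 stays open, as does whether the ring or the nitrogen drives the change.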